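Cyclohexyl for allyl on an enaminone amine nitrogen

The source may report more compounds than this note shows. Statements on the series, on what has been measured and on what is new or still open speak of the compounds shown alone.

Compound 1 `C=CCNC(=C\C(=O)/C=C/c1ccc(O)c(OC)c1)/C=C/c1ccc(O)c(OC)c1` was tested in a functional assay on EA.hy 926 cells (Homo sapiens), read by fluorescence, tested at 10 uM (a higher number here means a stronger effect of the compound at the concentration tested, a lower number a weaker effect), and gave 267%. Compound 2 `COc1cc(/C=C/C(=O)/C=C(/C=C/c2ccc(OC(C)=O)c(OC)c2)NC2CCCCC2)ccc1OC(C)=O` gave 113% in this assay, so compound 1 stands highest of the two numbers, with compound 2 well beyond the scatter below it. Compound 2 differs from compound 1 in more than one place, so its value alone does not isolate any single change.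

Compound 3 `COc1cc(/C=C/C(=O)/C=C(/C=C/c2ccc(O)c(OC)c2)NC2CCCCC2)ccc1O` has not yet been measured in this assay. It differs from compound 1 in one place: cyclohexyl in place of allyl on an amine nitrogen. For the measured compounds named here, no single-change step has been measured, so the effect of this replacement is judged from the two values above. The change is estimated to give a step of a number 77 percentage points lower from compound 1 to compound 3 (beyond the scatter), a decrease beyond the usual scatter. Compound 3 is therefore expected to give about 190% in this assay, most likely between 110% and 270%.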

Compound 3, a percentage reported as activity, at one concentration (the size of the read-out at that concentration, not a potency): 191%
The estimate for compound 3 lay 1 percentage points below the measured number; the measured number falls inside the stated range.
By their numbers in this assay, from the lowest: compound 2; then compound 3; then compound 1.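

Measured alone, with the rest of the core unchanged, cyclohexyl in place of allyl on the amine nitrogen gives a number 76 percentage points lower from compound 1 to compound 3 (beyond the scatter) in this assay, so the group on this nitrogen clearly affects the read-out. The change does not abolish the effect at the concentration tested, as compound 3 still gives 191% in this comparison. No measurement given here accounts for the direction or size of this step.

The compounds shown leave open whether the fall follows from the larger group, the loss of the double bond outside aromatic rings or the ring itself; a propyl chain, a cyclopropyl group or a phenyl group on the same nitrogen would help to separate these. Going by these compounds, it also remains open whether the step would carry over to other variants of the core.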